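This account rests on a few compounds, and the source may have more. Where it says the series, first, only, none or still open, it means among the compounds named here.

Working notes on the series.

Compound 1 `Fc1ccc(C2CC(c3ccccc3)=NN2c2ccc(-c3ccccc3)nn2)cc1` is the reference. In a functional assay on A549 cells (Homo sapiens) for antiproliferative activity, read by MTT assay, with a stated time of 24 h (a lower number here means a stronger inhibitor, a higher number a weaker inhibitor), compound 1 gives 89200 nM. Compound 2 `FC(F)(F)c1ccc(C2CC(c3ccccc3)=NN2c2ccc(-c3ccccc3)nn2)cc1` carries trifluoromethyl in place of fluoro on an aromatic carbon and in this assay compound 2 gives 9160 nM, so that the change makes the step of a 9.7-fold lower number from compound 1 to compound 2 (0.99 log units; beyond the scatter).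

Compound 3 `COc1ccc(C2=NN(c3ccc(-c4ccccc4)nn3)C(c3ccc(F)cc3)C2)cc1` differs from compound 1 by methoxy in place of hydrogen on an aromatic carbon. In this assay compound 3 reaches only the limit of the assay, > 100000 nM. The step of an at least 1.1-fold higher number from compound 1 to compound 3 (0.04 log units; that floor lies within the scatter) is therefore a floor and no more, set by the limit of > 100000 nM in this assay, at which 1 of the 3 values shown sits.

Compound 4 `COc1ccc(C2=NN(c3ccc(-c4ccccc4)nn3)C(c3ccc(C(F)(F)F)cc3)C2)cc1` has not been measured in this assay. It differs from compound 3 by trifluoromethyl in place of fluoro on an aromatic carbon, the same change as that from compound 1 to compound 2, at the same place as there. For the measured compounds named here, the only measured instance of this change is the step of a 9.7-fold lower number from compound 1 to compound 2 (0.99 log units; beyond the scatter), which was beyond the scatter. Carrying that step over from compound 3, whose value is known only as a limit, gives for compound 4 an expected step of an at least 4.0-fold lower number from compound 3 to compound 4 (0.60 log units; beyond the scatter), resting on the step from compound 1 to compound 2 alone. Since compound 3 itself is unplaced above the limit, the expected value of compound 4 is wide: the estimate for compound 4 in this assay is 25000 nM, expected between 8000 nM and 100000 nM, with a real chance that compound 4 also returns only a limit.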

Compound 4, half-maximal inhibitory concentration: > 100000 nM
Compound 4 gave a limit, no number; the forecaster's own chance of this, stated with the estimate: 30%; middle value at least 4.0-fold (0.60 log units) from the limit.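

In this assay compound 4 returns > 100000 nM, a limit of the assay and not a number. With compound 3 also at a limit, the step from fluoro to trifluoromethyl on the methoxy-bearing core cannot be read, so the lower number seen for this change on the core of compound 1 is neither confirmed nor contradicted on the second core: the limit of > 100000 nM in this assay, at which 2 of the 4 values shown sit. What can be read is the methoxy change on the trifluoromethyl side, an at least 10-fold higher number from compound 2 to compound 4 (1.03 log units; beyond the scatter), and setting it beside the same change on the fluoro side does not settle whether that change has the same size on both: the same change on two cores in this assay, an at least 1.1-fold higher number (0.04 log units; that floor lies within the scatter) from compound 1 to compound 3 and an at least 10-fold higher number (1.03 log units; beyond the scatter) from compound 2 to compound 4; the limit leaves it open whether they differ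

On these data alone, it remains open whether trifluoromethyl in place of fluoro lowers the number at all once methoxy is present, a question that only a compound on this core with a measured number rather than a limit in this assay could begin to answer. Also open, as far as these compounds go, is how other groups would read in this assay, such as an amine or a carboxylic acid where the methoxy stands, or a nitrile where the trifluoromethyl stands.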